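This account rests on a few compounds, and the source may have more. Where it says the series, first, only, none or still open, it means among the compounds named here.

Measured compounds:
compound 1, `O=C(NC/C=C\Cn1ccc(=O)[nH]c1=O)c1ccccc1`: 4900 nM
compound 2, `O=C(NC/C=C\Cn1cc(F)c(=O)[nH]c1=O)c1ccccc1`: > 100000 nM
compound 3, `Nc1ccn(C/C=C\CNC(=O)c2ccccc2)c(=O)n1`: > 100000 nM

These three compounds were tested in a functional assay on HeLa cells (Homo sapiens) for cytotoxicity, read by MTT assay, with a stated time of 72 h; on this read-out lower numbers stand for stronger inhibition and higher numbers for weaker inhibition. Compound 1 gives 4900 nM. For compound 2 the value > 100000 nM is a limit of the assay, not a number. For compound 3 the value > 100000 nM is likewise a limit, not a number. Two of the three values therefore sit at the limit of > 100000 nM in this assay, at which 2 of the 3 values shown sit.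

Compound 1 and compound 2 differ in one place: fluoro in place of hydrogen on an aromatic carbon. That change produced an at least 20-fold higher number from compound 1 to compound 2 (1.30 log units; beyond the scatter). Compound 3 carries a different core from compound 1, and the difference between the two cores is not broken down here.

Compound 4, `Nc1ccn(C/C=C\CNC(=O)c2ccc(F)cc2)c(=O)n1`, is not yet measured. It differs from compound 3 by fluoro in place of hydrogen on an aromatic carbon. Going by the values given here, this is the same kind of change as the one from compound 1 to compound 2, but it lands in a different place: there the fluoro entered a six-membered aromatic ring with 2 nitrogen, ortho to a group of 1 heavy atom, two atoms from the ring nitrogen, meta to a large group and para to a group of 1 heavy atom; here it enters a six-membered aromatic ring of carbon only, para to a large group.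

The expectation for compound 4 rests on compound 3 giving only the limit > 100000 nM and on the earlier fluoro step, which from compound 1 to compound 2 gave an at least 20-fold higher number from compound 1 to compound 2 (1.30 log units; beyond the scatter), a move toward weaker inhibition. Compound 4 is therefore expected to remain at or beyond the same limit, which amounts to an estimated step that the limit leaves unreadable from compound 3 to compound 4. The estimate for compound 4 in this assay is 150000 nM, expected to fall between 50000 nM and 500000 nM.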

Compound 4, half-maximal inhibitory concentration: > 100000 nM
Compound 4 gave a limit, no number (the forecaster's own chance of this, stated with the estimate: 85%); the middle value lies beyond the limit too.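

Compound 3 and compound 4 both end at a limit of the assay rather than a number, so the change from phenyl to 4-fluorophenyl gives no step that can be read: the limit of > 100000 nM in this assay, at which 3 of the 4 values shown sit.

Going by these compounds alone, what stays open is whether that change alters inhibition at all, in either direction, and what it would do on the core of compound 1, the only compound here with a number.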